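Adding a butyl group on the alkyne-side ring of compound 3

A few compounds are considered here, and "the series" means these few. Any claim that something is new, unique, unknown or untested is made for them only; others in the source may bear on it.

This series rests on a shared core carrying two aryl groups. In an ADME assay on HEL cells (Homo sapiens) for cytotoxicity, read by cell counting, with a stated time of 3 days (on this read-out lower numbers stand for higher toxicity in this test and higher numbers for lower toxicity in this test), compound 1 `CCCCCc1ccc(-c2oc3nc(=O)n([C@H]4C[C@H](OC(C)=O)[C@@H](COC(C)=O)O4)cc3c2C#Cc2ccc(C)cc2)cc1` gives 100000 nM, compound 2 `CCCCCc1ccc(C#Cc2c(-c3ccc(CCCCC)cc3)oc3nc(=O)n([C@H]4C[C@H](OC(C)=O)[C@@H](COC(C)=O)O4)cc23)cc1` gives 100000 nM, and compound 3 `CC(=O)OC[C@H]1O[C@@H](n2cc3c(C#Cc4ccc(C)cc4)c(-c4ccc(C)cc4)oc3nc2=O)C[C@@H]1OC(C)=O` gives 60000 nM. Among the compounds with values here, compound 3 stands within the scatter of both of the others, so on these three numbers no compound can be told apart from the rest in this assay.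

The next compound, compound 4 `CCCCCc1ccc(C#Cc2c(-c3ccc(C)cc3)oc3nc(=O)n([C@H]4C[C@H](OC(C)=O)[C@@H](COC(C)=O)O4)cc23)cc1`, differs from compound 3 in one place: butyl in place of hydrogen on a saturated chain carbon bound to an aromatic carbon.

Within the data shown here, two measured steps bear on this change. The closest match is the step from compound 1 to compound 2, where the same butyl enters at the same kind of place, and there this assay showed no change at the digits printed from compound 1 to compound 2 (within the scatter). The reverse change, a butyl leaving, is seen in the step from compound 1 to compound 3, where this assay showed a 1.7-fold lower number from compound 1 to compound 3 (0.22 log units; within the scatter). Both steps stay inside the scatter, so for compound 4 the expected step is a 1.3-fold higher number from compound 3 to compound 4 (0.12 log units; within the scatter), with no direction that can be trusted.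

The estimate for compound 4 in this assay is therefore 80000 nM, with a range from 40000 nM to 160000 nM.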

Compound 4, minimum cytotoxic concentration: 20000 nM
Estimate against measurement, compound 4: 4.0-fold (0.60 log units) above; measured number below the stated range.
By their numbers in this assay, from the lowest: compound 4; then compounds 3, 1 and 2 (each within the scatter of the next).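

In this assay, butyl in place of hydrogen on a saturated chain carbon bound to an aromatic carbon now gives a step beyond the scatter, a 3.0-fold lower number from compound 3 to compound 4 (0.48 log units; beyond the scatter), and this lower number stands for higher toxicity in this test. Hydrogen in place of butyl also gives a step beyond the scatter, a 5.0-fold lower number from compound 2 to compound 4 (0.70 log units; beyond the scatter), yet the size of that step depends on the core that carries the change: the same change on two cores in this assay, a 1.7-fold lower number (0.22 log units; within the scatter) from compound 1 to compound 3 and a 5.0-fold lower number (0.70 log units; beyond the scatter) from compound 2 to compound 4, 3.0-fold (0.48 log units) apart, beyond the scatter of two such steps The butyl change therefore cannot be read as one fixed effect at this kind of place, because its result differs with the rest of the molecule: the same change on two cores in this assay, no change at the digits printed (within the scatter) from compound 1 to compound 2 and a 3.0-fold lower number (0.48 log units; beyond the scatter) from compound 3 to compound 4, 3.0-fold (0.48 log units) apart, beyond the scatter of two such steps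

The compounds shown leave open whether this drop belongs to butyl itself, or whether a shorter propyl or a longer octyl in the same place would give a similar number. They also leave open whether an amine or a carboxylic acid on the chain would keep the lower number of compound 4 or bring it back towards that of compound 3.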